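Moving the oxolane attachment point on a shared core

The source may hold more compounds than are shown below. What is called first, only, known or untested is meant among the compounds shown, and "the series" means these compounds.

Among the measured compounds shown here, compound 1 `Cc1cc(C)c(CN2CCc3c(Cl)cc([C@H](CO)[C@H]4CCOC4)c(Cl)c3C2=O)c(=O)[nH]1` is the one compound here with a single number in an assay for inhibition of histone-lysine N-methyltransferase EZH2 variant Y641N (Homo sapiens), read by scintillation counting, with a stated time of 60 min, in the presence of a further agent that is not named here (on this read-out lower numbers stand for stronger inhibition and higher numbers for weaker inhibition), where compound 1 gives 0.24 nM. Compound 2 `COC(c1cc(Cl)c2c(c1Cl)C(=O)N(Cc1c(C)cc(C)[nH]c1=O)CC2)C1CCOC1` has several entries in this assay that do not settle on one value, giving 130 nM; 30 nM; 1.9 nM; 0.6 nM (4 entries), as seen in the several entries of compound 2 in this assay, 130 nM; 30 nM; 1.9 nM; 0.6 nM (4 entries). Compound 3 `COC(c1cc(Cl)c2c(c1Cl)C(=O)N(Cc1c(C)cc(C)[nH]c1=O)CC2)C1CCOCC1` likewise spreads widely, giving 310 nM; 0.1 nM (2 entries), as seen in the several entries of compound 3 in this assay, 310 nM; 0.1 nM (2 entries). Compound 4 `Cc1cc(C)c(CN2CCc3c(Cl)cc([C@H](CO)[C@H]4CCCO4)c(Cl)c3C2=O)c(=O)[nH]1` has not been measured. It differs from compound 1 by oxolan-2-yl in place of oxolan-3-yl on a saturated chain carbon bound to an aromatic carbon and a saturated chain carbon; the two hold the same atoms, joined differently. For the measured compounds named here, with no measured step between compounds to lean on, the expected change from compound 1 to compound 4 in this assay is a 1.7-fold higher number from compound 1 to compound 4 (0.22 log units; within the scatter), a step not beyond the usual scatter. Compound 4 is therefore estimated at 0.4 nM, within a range from 0.1 nM to 2 nM.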

Compound 4, inhibition constant: 8 nM
Compound 4: the middle estimate sits 20-fold (1.30 log units) below what was measured; measured number outside the range, above it.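

Replacing oxolan-3-yl with oxolan-2-yl, the same atoms joined differently, gives a 33-fold higher number from compound 1 to compound 4 (1.52 log units; beyond the scatter) in this assay, so this place responds to how the ring is attached and not only to which atoms it holds. Among the compounds shown here, no earlier pair offered such a one-place comparison, and a single step calls for caution, as entries for similar compounds can spread widely: the several entries of compound 2 in this assay, 130 nM; 30 nM; 1.9 nM; 0.6 nM (4 entries). The same caution applies to a second compound: the several entries of compound 3 in this assay, 310 nM; 0.1 nM (2 entries).

The compounds shown leave open how this place would respond to an amine or a carboxylic acid in place of the oxolane ring. Going by these compounds, whether this step would hold on a shared core other than that of compound 1 also remains open.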